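Six-membered to five-membered ring exchange on compound 1

The compounds below may be only part of what the source reports. "The series", "measured", "known", "first", "only" and "open" are said of these compounds alone.

Of the compounds shown here, three have been read in a functional assay on CEM13 cells (Homo sapiens) for cytotoxicity, read by MTT assay, with a stated time of 72 h; on this read-out lower numbers stand for stronger inhibition and higher numbers for weaker inhibition. For the measured compounds named here, compound 1 `Cc1c(C)c2c(c(C)c1OC(=O)CCC(=O)NC1CC(C)(C)N([O])C(C)(C)C1)CC[C@@](C)(CCC[C@H](C)CCC[C@H](C)CCCC(C)C)O2` gives 146000 nM, the only actual number in the set. Compound 2 `Cc1c(C)c2c(c(C)c1O)CCC(C)(C(=O)NC1CC(C)(C)N([O])C(C)(C)C1)O2` returns only a limit of the assay, > 300000 nM. Compound 3 `Cc1c(C)c2c(c(C)c1OC(=O)CCC(=O)O)CCC(C)(C(=O)NCC1CC(C)(C)N([O])C1(C)C)O2` also returns only a limit, > 300000 nM. The top of the readable scale is therefore marked by the limit of > 300000 nM in this assay, at which 2 of the 3 values shown sit. Going by the values given here, compound 1 is the only compound with a position on the scale, and compounds 2 and 3 cannot be ranked against each other.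

The next compound to be read is compound 4 `Cc1c(C)c2c(c(C)c1OC(=O)CCC(=O)NC1CC(C)(C)N([O])C1(C)C)CC[C@@](C)(CCC[C@H](C)CCC[C@H](C)CCCC(C)C)O2`, which keeps the core of compound 1 and differs only in the group on an amide-type nitrogen: a group of 10 heavy atoms (8 carbon, 1 nitrogen, 1 oxygen; one five-membered non-aromatic ring with 1 hetero atom) in place of a group of 11 heavy atoms (9 carbon, 1 nitrogen, 1 oxygen; one six-membered non-aromatic ring with 1 hetero atom), on an amide-type nitrogen. Among the compounds with values here, no pair of measured compounds shows this exchange, so its size in this assay cannot be read from the data. Compound 1 at 146000 nM is the sole anchor for the expectation. Within the data shown here, with one ring member fewer as the only change, no shift beyond the usual scatter is expected, and neither direction is favoured. The expected step of a 1.0-fold higher number from compound 1 to compound 4 (0.01 log units; within the scatter) is therefore small. Compound 4 is estimated at 150000 nM, with an expected range from 70000 nM to 300000 nM.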

Compound 4, half-maximal inhibitory concentration: > 300000 nM
Compound 4: only a limit was reported (the forecaster's own chance of this, stated with the estimate: 20%); middle value at least 2.0-fold (0.30 log units) away from the limit.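

Working notes on the position: in this assay, the amide-type nitrogen is the first place in the series where a single exchange can be read, and the group with one five-membered non-aromatic ring with 1 hetero atom, in place of the group with one six-membered non-aromatic ring with 1 hetero atom, gives an at least 2.0-fold higher number from compound 1 to compound 4 (0.31 log units; beyond the scatter). Compound 4 gives > 300000 nM, which is a limit of the assay and not a number. The step therefore fixes only a direction and a minimum size, showing that the loss of one ring member on this nitrogen is not silent on the core of compound 1, and the size stays open because the read-out ends at the top of its scale: the limit of > 300000 nM in this assay, at which 3 of the 4 values shown sit.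

On these data alone, how far compound 4 lies past that limit remains open, and with it whether the step is modest or large. The compounds shown also leave open how this nitrogen responds to a group outside this ring pair, such as a plain cyclohexyl ring or a longer open alkyl chain, and whether any such group would read below compound 1 on the scale.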